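A second hydroxymethyl group in place of the propyl chain

This account rests on a few compounds, and the source may have more. Where it says the series, first, only, none or still open, it means among the compounds named here.

Compound 1 `CCCCCCCOc1ccc(CCC(N)(CO)CCCC)cc1` and compound 2 `CCCCCCCOc1ccc(CC[C@](N)(CO)CCC)cc1` share one core and differ only in the amino alcohol head. In a functional assay on the whole organism (T-cell) with Rattus norvegicus as the target, with a stated time of 4 days (on this read-out higher numbers stand for an effect only at larger amounts of compound and lower numbers for an effect already at smaller amounts), compound 1 gives > 10 mg/kg, a limit of the assay. In this assay compound 2 gives > 10 mg/kg, likewise a limit. The step that the two limits leave unreadable from compound 1 to compound 2 is unreadable since (the limit of > 10 mg/kg in this assay, at which 2 of the 2 values shown sit). Compound 3 `CCCCCCCOc1ccc(CCC(N)(CO)CO)cc1` carries 1-amino-2-hydroxy-1-(hydroxymethyl)ethyl in place of 1-amino-1-(hydroxymethyl)butyl on a saturated chain carbon, two bonds along the chain from an aromatic carbon. No readable measured step bears on this change, so the expected step that the limit leaves unreadable from compound 2 to compound 3 is no larger than the scatter. Compound 3 is therefore estimated at 20 mg/kg, between 5 mg/kg and 100 mg/kg, most probably reported again only as a limit.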

Compound 3, dose for 50% inhibition: 0.014 mg/kg
For compound 3 the middle estimate is 1400-fold (3.15 log units) above the measured one; the measured number lies below the stated range.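

In this assay, among the compounds shown here, this change is the first at this position to give a readable number: 1-amino-2-hydroxy-1-(hydroxymethyl)ethyl in place of 1-amino-1-(hydroxymethyl)butyl brings an at least 710-fold lower number from compound 2 to compound 3 (2.85 log units; beyond the scatter), and likewise an at least 710-fold lower number from compound 1 to compound 3 (2.85 log units; beyond the scatter). Both steps are large, yet each is a bound and not a full size: the limit of > 10 mg/kg in this assay, at which 2 of the 3 values shown sit.

The compounds shown leave open how much of this effect would remain with an aminomethyl or a methyl group in place of the second hydroxymethyl. They also leave open how far the true values of compound 1 and compound 2 lie from their limits.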